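Compound 3 and its unmeasured relative compound 4

A few compounds are considered here, and "the series" means these few. Any claim that something is new, unique, unknown or untested is made for them only; others in the source may bear on it.

Results in a functional assay on HL-60 cells (Homo sapiens) for inhibition, read by MTT assay, with a stated time of 72 h (a lower number here means a stronger inhibitor, a higher number a weaker inhibitor), are as follows.

- compound 1 `COc1ccc(-c2nc(C)oc2C(=O)N2CCN(c3cccc(Cl)c3)CC2)cc1OC` gives "not active" (no number reported)
- compound 2 `COc1cccc(-c2nc(C)oc2C(=O)N2CCN(c3cccc(Cl)c3)CC2)c1` gives "not active" (no number reported)
- compound 3 `COc1cc(-c2nc(C)oc2C(=O)N2CCN(c3cccc(Cl)c3)CC2)ccc1O` gives 85.9 nM

For the measured compounds named here, compound 3 stands alone here: at 85.9 nM it is the only compound with a number in this assay, while the other two were reported without one. Compound 4 `COc1cc(-c2nc(C)oc2C(=O)N2CCN(c3cccc(Cl)c3)CC2)ccc1OP(=O)(O)O` has not yet been measured. The change from compound 3 to compound 4 is a group of 4 heavy atoms (3 oxygen, 1 phosphorus; no ring) in place of a hydrogen atom, on an oxygen on an aromatic ring, a group of 4 heavy atoms in place of a hydrogen atom, on an oxygen on an aromatic ring.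

Going by the values given here, no measured step shows the size of such a change. Compound 1 gives "not active" (no number reported) and compound 2 gives "not active" (no number reported), and neither has a hydrogen on an oxygen on an aromatic ring. This points, weakly, towards a weaker inhibitor. The expected change is a 1.5-fold higher number from compound 3 to compound 4 (0.18 log units; within the scatter), a modest estimate with wide uncertainty. For compound 4 the estimated value is 130 nM, with an expected range from 40 nM to 600 nM.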

Compound 4, half-maximal inhibitory concentration: 303 nM
For compound 4 the middle estimate is 2.3-fold (0.37 log units) below the measured one, within the range that was stated.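

In this assay, placing this group on the oxygen on an aromatic ring gives a 3.5-fold higher number from compound 3 to compound 4 (0.55 log units; beyond the scatter), so compound 4 is a weaker inhibitor than compound 3 but still has a measured value. Compound 1, which also has no hydrogen on an oxygen on an aromatic ring, gives "not active" (no number reported), so the loss of that hydrogen alone does not decide whether a compound has a number in this assay. Nothing given here accounts for the size of this step.

Going by these compounds, it remains open how a different group on this oxygen, such as an acetyl group or a short chain ending in a carboxylic acid, would compare with compound 3. The compounds shown also leave open whether the effect of this change would hold on a core with a different substituent in place of the chlorine.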